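Benzylsulfanyl Replaces Methylamino on a Weakly Active Core

The compounds below may be only part of what the source reports. "The series", "measured", "known", "first", "only" and "open" are said of these compounds alone.

Compound 1 `OCC(CO)OCn1c(Cl)nc2c(Cl)c(Cl)ccc21` and compound 2 `CNc1nc2c(Cl)c(Cl)ccc2n1COC(CO)CO` share a core and were both tested in a functional assay on KB cells (Homo sapiens) for inhibition; a higher number here means a weaker inhibitor, a lower number a stronger inhibitor. In this assay compound 1 gives > 100000 nM, which is a limit of the assay rather than a number. Compound 2 gives > 100000 nM, again a limit and not a number. The step that the two limits leave unreadable from compound 1 to compound 2, methylamino in place of chloro on an aromatic carbon, therefore cannot be sized, since both values sit at the limit of > 100000 nM in this assay, at which 2 of the 2 values shown sit. Compound 3 `OCC(CO)OCn1c(SCc2ccccc2)nc2c(Cl)c(Cl)ccc21` differs from compound 2 by benzylsulfanyl in place of methylamino on an aromatic carbon. Among the measured compounds shown here, no measured step concerns this change, and the only measured step is itself unreadable, so there is no basis for expecting a clear shift in either direction. Compound 3 is therefore estimated at 80000 nM, with a range from 5000 nM to 300000 nM. The expected step is an at least 1.2-fold lower number from compound 2 to compound 3 (0.09 log units; that floor lies within the scatter), with a real chance that only a limit is reported again.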

Compound 3, half-maximal inhibitory concentration: 60000 nM
Beside the measured number, compound 3's estimate is 1.3-fold (0.12 log units) above it; low and high end bracket the measured number.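

With benzylsulfanyl on the aromatic carbon between two ring nitrogen atoms, compound 3 gives 60000 nM in this assay, the only real number among the compounds shown. Replacing methylamino gives an at least 1.6-fold lower number from compound 2 to compound 3 (0.22 log units; that floor lies within the scatter), and replacing chloro gives an at least 1.6-fold lower number from compound 1 to compound 3 (0.22 log units; that floor lies within the scatter). Both floors lie within the scatter and both steps start from a limit, while the step between the other two compounds cannot be read, so a group carrying a six-membered aromatic ring is compatible with a measurable value here, but no real gain is established: the limit of > 100000 nM in this assay, at which 2 of the 3 values shown sit.

Still open, as far as these compounds go, is which part of benzylsulfanyl matters, the sulfur or the aromatic ring; a methylsulfanyl or a benzylamino group at this position would separate the two. Also open, from the compounds shown here alone, is whether any group here can bring the number far below that of compound 3.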